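A few compounds are considered here, and "the series" means these few. Any claim that something is new, unique, unknown or untested is made for them only; others in the source may bear on it.

Compound 1 `Cc1cn(-c2cc(NC(=O)c3ccc(C)c(Nc4nccc(-c5ccccc5)n4)c3)cc(N3CCN(C)CC3)c2)cn1` gives 2.16 h in an ADME assay on the whole organism (Mus musculus, strain CD1), read by LC-MS, using cassette dosing, with a stated time of 24 h, at a dose of 0.4 mg/kg by the intravenous route; a lower number here means that the compound disappears faster, a higher number that the compound lasts longer.
Compound 2 `Cc1cn(-c2cc(NC(=O)c3ccc(C)c(Oc4ccccc4)c3)cc(C(F)(F)F)c2)cn1` gives 2.27 h in this assay.

Among the compounds with values here, only these two numbers exist in this assay so far, and they sit within the usual scatter of each other, so compound 2 stands level with compound 1 rather than apart from it. Within the data shown here, no step between two measured compounds that differ in a single place is available, and the two measured structures differ in more than one place, so their values show only that both keep a similar mean residence time.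

Compound 3 `Cc1cn(-c2cc(NC(=O)c3ccc(C)c(Oc4ccccc4)c3)cc(N3CCN(C)CC3)c2)cn1` is the next member. It differs from compound 2 in one place: 4-methylpiperazin-1-yl in place of trifluoromethyl on an aromatic carbon. The same 4-methylpiperazin-1-yl group is already present in compound 1, which with 2.16 h lies close to compound 2, so for this exchange no step beyond the scatter is expected in this assay, in either direction. Compound 3 is therefore estimated at 2.2 h, with a range of 1.1 h to 4.4 h, which corresponds to an expected step of a 1.0-fold lower number from compound 2 to compound 3 (0.01 log units; within the scatter).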

Compound 3, mean residence time: 8.98 h
Estimate against measurement, compound 3: 4.1-fold (0.61 log units) below, outside the stated range (above it).
By their numbers in this assay, from the lowest: compounds 1 and 2 (each within the scatter of the next); then compound 3.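

In this assay, within the data shown here, replacing trifluoromethyl with 4-methylpiperazin-1-yl on this aromatic carbon gives a 4.0-fold higher number from compound 2 to compound 3 (0.60 log units; beyond the scatter), the first single-place step and evidence that this position can affect how long the compound lasts. The presence of 4-methylpiperazin-1-yl alone does not go with the longest residence time among the compounds shown: compound 1, which carries the same group on a different remainder, gives 2.16 h, so the gain is established only for the exchange on the scaffold of compound 2. No measurement bears on what lies behind this step.

This single pair does not separate the contribution of the six-membered ring from that of its two nitrogens or the terminal methyl. It also leaves open whether a morpholine, an unsubstituted piperazine or an open-chain dimethylamino group at the same position would give a similar step, and whether the exchange would carry over to the remainder of compound 1.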